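Fluorine count on a fluoroalkyl chain and lipophilicity

The compounds below may be only part of what the source reports. "The series", "measured", "known", "first", "only" and "open" are said of these compounds alone.

Compound 1 `CC(=O)N1CCC[C@H]1C(=O)OCC(F)F` and compound 3 `CC(=O)N1CCC[C@H]1C(=O)OCC(F)(F)F` share one core; compound 2 `OCCCC(F)(F)CF` and compound 4 `OCCCC(F)(F)C(F)F` share another, and the difference between the two cores is not broken down here. In a physicochemical assay for lipophilicity, read by NMR (on this read-out lower numbers stand for lower lipophilicity and higher numbers for higher lipophilicity), compound 1 gives 0.02 and compound 3 gives 0.55. The change between these two, (fluoro in place of hydrogen on a saturated chain carbon bound to two fluorine atoms and a saturated chain carbon), made a step of a number 0.53 log units higher from compound 1 to compound 3 (beyond the scatter). In this assay compound 2 gives 0.58, a number close to that of compound 3 and well apart from that of compound 1. Compound 4 carries the same kind of change on its own core, (fluoro in place of hydrogen on a saturated chain carbon bound to a fluorine atom and a saturated chain carbon); what differs around the place is that here the saturated chain carbon is bound to a fluorine atom, whereas in the earlier pair it is bound to two fluorine atoms. Because of the step of a number 0.53 log units higher from compound 1 to compound 3 (beyond the scatter) seen with compound 1, a step from compound 2 to compound 4 of a number 0.35 log units higher from compound 2 to compound 4 (beyond the scatter) is expected in this assay, somewhat smaller since the two places are not the same. For compound 4 the expected value is 0.93, estimated to fall between 0.6 and 1.3.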

Compound 4, partition coefficient: 0.97
The estimate for compound 4 lay 0.04 log units below the measured number; the measured number falls inside the stated range.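

In this assay, the fluoromethyl to difluoromethyl change on the core of compound 2 gives a number 0.39 log units higher from compound 2 to compound 4 (beyond the scatter), and the fluoro for hydrogen change on the core of compound 1 gives a number 0.53 log units higher from compound 1 to compound 3 (beyond the scatter), so both steps run in the same direction and both lie beyond the scatter. This shows that, in these two pairs, adding one more fluoro to a fluorinated chain carbon goes with a higher number on both cores, and neither pair goes against that; it does not show a general rule, since two pairs are few and they differ in core as well as in the place of the change. Nothing shown bears on why either step arises.

From the compounds shown here alone, whether a step of this kind holds on the core of compound 2 with an amine or a carboxylic acid in place of the hydroxyl group stays open. Also open, going by these compounds, is how it reads on a longer chain, and how the fluoromethyl to difluoromethyl change reads on the core of compound 1.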